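From chloro to methoxy on a single aromatic ring

The compounds below may be only part of what the source reports. "The series", "measured", "known", "first", "only" and "open" are said of these compounds alone.

Compound 1 `CC(C)n1c(S)nnc1CSc1nnc(-c2ccccc2)n1-c1ccccc1`: "not determined" (no result reported)
Compound 2 `Sc1nnc(CSc2nnc(-c3ccccc3)n2-c2ccccc2)n1-c1ccc(Cl)cc1`: 50300 nM

In a functional assay on MDA-MB-231 cells (Homo sapiens) for inhibition, read by MTT assay, with a stated time of 48 h (a lower number here means a stronger inhibitor, a higher number a weaker inhibitor), compound 2 gives 50300 nM. Going by the values given here, this is the only number available, so compound 2 cannot yet be ranked against anything. Compound 3 `COc1ccc(-n2c(S)nnc2CSc2nnc(-c3ccccc3)n2-c2ccccc2)cc1` differs from compound 2 in one place: methoxy in place of chloro on an aromatic carbon. This puts methoxy in place of chloro on an aromatic carbon, para to a large group. Among the compounds with values here, no measured step between similar compounds offers a guide, so no shift beyond the usual scatter is expected in this assay. The expected change is a 1.1-fold lower number from compound 2 to compound 3 (0.05 log units; within the scatter). For compound 3 the estimated value is 45000 nM, within an expected range of 18000 nM to 110000 nM.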

Compound 3, half-maximal inhibitory concentration: 29200 nM
Compound 3: the middle estimate sits 1.5-fold (0.19 log units) above what was measured; the measured number falls inside the stated range.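

In this assay, methoxy in place of chloro gives a 1.7-fold lower number from compound 2 to compound 3 (0.24 log units; within the scatter), so 4-chlorophenyl and 4-methoxyphenyl cannot be told apart at this position. The position therefore accepts either group, and the hydrogen-bond acceptor that enters with methoxy brings no shift beyond the scatter. No measured evidence is available to explain why the two compounds read alike. From the compounds shown here alone, whether an amine, a carboxylic acid or a longer chain on this aromatic carbon would shift the number beyond the scatter remains open. A single step also cannot establish a trend at this position.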